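Nitrooxy acyl series: paw edema inhibition notes

A few compounds are considered here, and "the series" means these few. Any claim that something is new, unique, unknown or untested is made for them only; others in the source may bear on it.

Measured in a functional assay on the whole organism (strain albino) for inhibition, with Rattus norvegicus as the target, read by paw edema, with stated times of 30 min and 1 h, at a dose of 100 mg/kg by the oral route; a lower number here means less inhibition, a higher number more inhibition at the dose given (going by the name of the read-out):
- compound 1, `COc1ccc(C2CC(c3ccc(OC)c(OC)c3)=NN2C(=O)CO[N+](=O)[O-])c(OC)c1`, gives 38%
- compound 2, `COc1ccc(C2=NN(C(=O)CO[N+](=O)[O-])C(c3c(Cl)cccc3Cl)C2)cc1OC`, gives 40%
- compound 3, `COc1ccc(C2CC(c3ccc(OC)c(OC)c3)=NN2C(=O)C(C)O[N+](=O)[O-])c(OC)c1`, gives 44%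

In this assay compound 1 gives 38% and compound 2 gives 40%; the step is a number 2 percentage points higher from compound 1 to compound 2 (within the scatter), and the change behind it is 2,6-dichlorophenyl in place of 2,4-dimethoxyphenyl on a saturated ring carbon. Compound 3 differs from compound 1 by methyl in place of hydrogen on a saturated chain carbon bound to a carbonyl carbon and an oxygen on an unsaturated carbon, giving a number 6 percentage points higher from compound 1 to compound 3 (within the scatter). Compound 3 stands with the highest number of the three, but its distances to compound 2 and compound 1 both lie within the scatter, so no order among the three can be claimed.

Compound 4, `COc1ccc(C2=NN(C(=O)C(C)O[N+](=O)[O-])C(c3c(Cl)cccc3Cl)C2)cc1OC`, is not yet measured in this assay. It differs from compound 3 by 2,6-dichlorophenyl in place of 2,4-dimethoxyphenyl on a saturated ring carbon. This is the same kind of change as from compound 1 to compound 2: what differs around the place is that in compound 3 the ring atom next to it bears a group of 8 heavy atoms, whereas in compound 1 it bears a ((nitrooxy)methyl)carbonyl group (7 heavy atoms); the two cores differ by methyl in place of hydrogen on a saturated chain carbon bound to a carbonyl carbon and an oxygen on an unsaturated carbon.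

Given that the earlier step was a number 2 percentage points higher from compound 1 to compound 2 (within the scatter), the expected step from compound 3 to compound 4 in this assay is a number 2 percentage points higher from compound 3 to compound 4 (within the scatter), resting on one precedent only. Compound 4 is thus estimated at 46%, expected to fall between 36% and 56%.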

Compound 4, a percentage reported as inhibition, in the whole organism at one dose (the size of the read-out at that dose, not a potency): 47%
The estimate for compound 4 lay 1 percentage points below the measured number; low and high end bracket the measured number.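

The change to 2,6-dichlorophenyl in place of 2,4-dimethoxyphenyl on a saturated ring carbon gives, in this assay, a step that is a number 3 percentage points higher from compound 3 to compound 4 (within the scatter), and it reads alike on the two cores: the same change on two cores in this assay, a number 2 percentage points higher (within the scatter) from compound 1 to compound 2 and a number 3 percentage points higher (within the scatter) from compound 3 to compound 4, 1 percentage points apart, within the scatter of two such steps

The methyl in place of hydrogen on the saturated chain carbon gives a step that is a number 7 percentage points higher from compound 2 to compound 4 (within the scatter), and it too reads alike on the two cores: the same change on two cores in this assay, a number 6 percentage points higher (within the scatter) from compound 1 to compound 3 and a number 7 percentage points higher (within the scatter) from compound 2 to compound 4, 1 percentage points apart, within the scatter of two such steps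

Within the data shown here, this shows only that the four compounds fit both changes carrying over from one core to the other without a detectable difference; since each single step lies within the scatter, it does not show that either change alters inhibition at all, and the agreement between small steps is weak evidence of true transfer, nor does it extend past these two groups or the one dose used.

The compounds shown leave open whether a change of larger effect would carry over in the same way, for instance an unsubstituted phenyl or a pyridyl on the saturated ring carbon, or an ethyl in place of the methyl on the chain carbon. They also leave open what the nitrooxy group itself contributes, since every compound shown carries it and none has a hydroxyl group in its place.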